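A few compounds are considered here, and "the series" means these few. Any claim that something is new, unique, unknown or untested is made for them only; others in the source may bear on it.

Of the compounds shown here, three have so far been tested in a functional assay on SK-N-SH cells (Homo sapiens) for inhibition; on this read-out higher numbers stand for weaker inhibition of growth and lower numbers for stronger inhibition of growth. Compound 1 `Cc1cnc2sn(-c3ccc(Br)cc3)c(=O)c2c1` gives 21300 nM in this assay. Compound 2 `O=c1ccsn1-c1ccc(Cl)c([N+](=O)[O-])c1` gives 23200 nM, and compound 3 `Cc1cc(C)c2c(=O)n(CC(=O)Nc3ccc(F)cc3C)sc2n1` gives 25700 nM. Compound 1 has the lowest of the three numbers, yet its gaps to compound 2 and to compound 3 both lie within the usual scatter, so the three cannot be told apart on these figures.

Compound 4 `O=c1c2cccnc2sn1-c1ccc(Br)cc1` has not yet been measured. It differs from compound 1 in a single place: hydrogen in place of methyl on an aromatic carbon. Among the compounds with values here, no pair of measured compounds differs in only one place, so there is no measured step to show how much such a change can move the number. The expectation therefore rests on compound 1 alone, which gives 21300 nM, and only a small step is expected, within the scatter: a 1.2-fold higher number from compound 1 to compound 4 (0.07 log units; within the scatter). Compound 4 is accordingly estimated at 25000 nM in this assay, with a range from 10000 nM to 60000 nM.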

Compound 4, concentration for 50% growth inhibition: 15200 nM
For compound 4 the middle estimate is 1.6-fold (0.22 log units) above the measured one; measured number inside the range.
By their numbers in this assay, from the lowest: compounds 4, 1, 2 and 3 (each within the scatter of the next).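

Hydrogen in place of methyl on this aromatic carbon gives a 1.4-fold lower number from compound 1 to compound 4 (0.15 log units; within the scatter) in this assay and provides the first measured step between two compounds that differ in one place. For this pair, the methyl group is not needed to keep the number at this level, since compound 1 and compound 4 cannot be told apart. No separate measurement bears on this result, so the small step has no explanation here.

The compounds shown compare only methyl and hydrogen on this carbon, so it remains open whether an amine, a carboxylic acid or a longer chain there would move the number beyond the scatter. On these data alone, it is also open whether the same swap would give so small a step with a different rest of the molecule.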